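A few compounds are considered here, and "the series" means these few. Any claim that something is new, unique, unknown or untested is made for them only; others in the source may bear on it.

Compound 1 `O=C(COc1ccc2c(=O)ccoc2c1)Nc1cccc(NC(=O)c2ccccc2)c1` gives 16 nM in an assay on isolated protein for inhibition of Rho-associated protein kinase 2 (Homo sapiens), read by scintillation counting, radiometric assay and 33P incorporation, with a stated time of 40 min, in the presence of a further agent that is not named here; on this read-out lower numbers stand for stronger inhibition and higher numbers for weaker inhibition; compound 2 `CC(C)(C)c1cc(C(=O)Nc2cccc(NC(=O)COc3ccc4c(=O)ccoc4c3)c2)no1` gives 5 nM.

Going by the values given here, compound 2 holds the lower of the two numbers, and the only measured step is a 3.2-fold lower number from compound 1 to compound 2 (0.51 log units; beyond the scatter). Compound 3 `NCc1ccc(C(=O)Nc2cccc(NC(=O)COc3ccc4c(=O)ccoc4c3)c2)cc1` differs from compound 2 by 4-(aminomethyl)phenyl in place of 5-(tert-butyl)-1,2-oxazol-3-yl on a carbonyl carbon. That measured step bears on this change only in part, since the entering group is a phenyl carrying an aminomethyl rather than the bare phenyl of compound 1, so the number is expected to move back toward that of compound 1. The expected step is a 3.0-fold higher number from compound 2 to compound 3 (0.48 log units; beyond the scatter), a modest rise in this assay. Compound 3 is estimated at 15 nM, within 4 nM to 60 nM.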

Compound 3, half-maximal inhibitory concentration: 66 nM
Compound 3: the middle estimate sits 4.4-fold (0.64 log units) below what was measured, outside the stated range (above it).
By their numbers in this assay, from the lowest: compound 2; then compound 1; then compound 3.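

In this assay this place on the carbonyl carbon proves more sensitive than the earlier pair showed, since the change to 4-(aminomethyl)phenyl gives a 13-fold higher number from compound 2 to compound 3 (1.12 log units; beyond the scatter) and counts as a large step. Aminomethyl in place of hydrogen on an aromatic carbon gives a 4.1-fold higher number from compound 1 to compound 3 (0.62 log units; beyond the scatter) as well, so the added group does not recover what the plain phenyl gave. Nothing at hand accounts for either step. As far as these compounds go, whether a carboxylic acid in place of the aminomethyl, or a longer chain ending in an amine, would bring the number nearer that of compound 2 stays open.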